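Compound 3 to compound 4: phenyl in place of methyl

The source may report more compounds than this note shows. Statements on the series, on what has been measured and on what is new or still open speak of the compounds shown alone.

Measured in a physicochemical assay for solubility (on this read-out higher numbers stand for higher solubility and lower numbers for lower solubility), across the series:
- compound 1 `COc1ccc(-n2cnc3cnc(-c4cccc(NC(C)=O)c4)cc32)cc1OC` gives 146000 nM
- compound 2 `CCOc1ccc(-n2cnc3cnc(-c4ccc(F)cc4C)cc32)cc1` gives 12000 nM
- compound 3 `Cc1cc(F)ccc1-c1cc2c(cn1)nc(C)n2-c1ccc(OC(F)F)cc1` gives 71000 nM

Compound 3 stands second highest of the three, with compound 1 nearest and compound 2 furthest; both gaps lie beyond the scatter. Compound 4 `Cc1cc(F)ccc1-c1cc2c(cn1)nc(-c1ccccc1)n2-c1ccc(OC(F)F)cc1` differs from compound 3 in one place, phenyl in place of methyl on an aromatic carbon and nothing else. Within the data shown here, no measured pair differs in one place, and the expectation rests on the structural change alone. A fall beyond the scatter is expected, estimated as a 4.7-fold lower number from compound 3 to compound 4 (0.68 log units; beyond the scatter) in this assay for this change. The estimated value for compound 4 is 15000 nM (4000 nM to 50000 nM).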

Compound 4, solubility: 6000 nM
For compound 4 the middle estimate is 2.5-fold (0.40 log units) above the measured one; the measured number falls inside the stated range.
By their numbers in this assay, from the lowest: compounds 4 and 2 (each within the scatter of the next); then compound 3; then compound 1.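

In this assay, among these compounds, phenyl in place of methyl on an aromatic carbon between two ring nitrogen atoms gives a 12-fold lower number from compound 3 to compound 4 (1.07 log units; beyond the scatter), the first single-place step and a large one. This position is therefore not indifferent to its substituent on this read-out. No measured evidence accounts for the fall.

With only methyl and phenyl shown here, it remains open whether the step follows the added carbon atoms or the aromatic ring itself. A cyclohexyl ring, an amine or a longer chain at this position would help separate the two.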